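The source may report more compounds than this note shows. Statements on the series, on what has been measured and on what is new or still open speak of the compounds shown alone.

In a functional assay on MCF7 cells (Homo sapiens) for cytotoxicity, read by MTT assay, with a stated time of 48 h (on this read-out higher numbers stand for weaker inhibition and lower numbers for stronger inhibition), compound 1 (`C/C(=N/NC(=S)Nc1ccccc1I)c1ccccn1`) gives 4.1 nM and compound 2 (`C/C(=N/NC(=S)Nc1ccccc1[N+](=O)[O-])c1ccccn1`) gives 5.7 nM on the same read-out. For the measured compounds named here, these two numbers lie within the usual scatter of each other, so compound 2 cannot be separated from compound 1, the only other compound measured so far. The next molecule, compound 3 (`C/C(=N/NC(=S)Nc1ccccc1Cl)c1ccccn1`), keeps the shared core and has chloro in place of nitro on an aromatic carbon, ortho to a large group (in counts: chloro in place of nitro on an aromatic carbon). Going by the values given here, the only measured step that bears on this is a 1.4-fold higher number from compound 1 to compound 2 (0.14 log units; within the scatter) and it put nitro in place of iodo on that same aromatic carbon. With this single step as a guide, no shift beyond the scatter is expected in this assay and neither direction is favoured. The estimated step is a 1.1-fold lower number from compound 2 to compound 3 (0.06 log units; within the scatter) and it rests on thin evidence. Compound 3 is therefore expected near 5 nM with an estimated range from 2 nM to 12 nM in this measurement.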

Compound 3, half-maximal inhibitory concentration: 0.16 nM
Compound 3: middle estimate off by 31-fold (1.49 log units), on the high side; measured number below the stated range.
By their numbers in this assay, from the lowest: compound 3; then compounds 1 and 2 (each within the scatter of the next).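

This position is far from indifferent to what sits on it: in this assay the change to chloro brings a 36-fold lower number from compound 2 to compound 3 (1.55 log units; beyond the scatter) and also a 26-fold lower number from compound 1 to compound 3 (1.41 log units; beyond the scatter) as a second large step, so the aromatic carbon ortho to a large group can move this read-out strongly. Being a halogen is not enough to give the low number, since iodo, also a halogen, stays with nitro in compounds 1 and 2 while chloro in compound 3 stands well apart from both. No measurement available here explains why chloro behaves so differently from the other two groups.

The three compounds shown vary only this one position, so it remains open whether fluoro or bromo would stay with chloro or fall back to the level of iodo and nitro, and whether a small non-halogen group such as methyl or an amine would do the same. Going by these compounds, it also remains open whether chloro at another carbon of the same ring would keep the low number of compound 3 or lose it.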